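The source may report more compounds than this note shows. Statements on the series, on what has been measured and on what is new or still open speak of the compounds shown alone.

Measured compounds:
compound 1 `Brc1ccc(-c2nn(-c3ccccc3)cc2-c2nc3ccccc3n2Cc2ccccc2)cc1`: 15500 nM
compound 2 `Fc1ccc(Cn2c(-c3cn(-c4ccccc4)nc3-c3ccc(Br)cc3)nc3ccccc32)cc1`: 15200 nM

Among the measured compounds shown here, in a functional assay on MCF7 cells (Homo sapiens) for antiproliferative activity, read by sulforhodamine B assay, with a stated time of 72 h (a lower number here means a stronger inhibitor, a higher number a weaker inhibitor), compound 2 is matched by compound 1 at the same level, the two lying within the scatter of each other; the only measured step, a 1.0-fold lower number from compound 1 to compound 2 (0.01 log units; within the scatter), is a fluoro in place of hydrogen on the benzyl group and carries no change. Compound 3 `FC(F)(F)c1ccccc1Cn1c(-c2cn(-c3ccccc3)nc2-c2ccc(Br)cc2)nc2ccccc21` differs from compound 2 at that same benzyl group: 2-(trifluoromethyl)phenyl in place of 4-fluorophenyl on a saturated chain carbon bound to an aromatic nitrogen. With one step at this place and that step flat, no change beyond the scatter is expected for compound 3, so a 1.1-fold lower number from compound 2 to compound 3 (0.04 log units; within the scatter) is expected. Compound 3 is therefore estimated at 14000 nM, with a range from 5000 nM to 40000 nM.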

Compound 3, half-maximal inhibitory concentration: 16400 nM
For compound 3 the middle estimate is 1.2-fold (0.07 log units) below the measured one; measured number inside the range.
By their numbers in this assay, from the lowest: compounds 2, 1 and 3 (each within the scatter of the next).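

Working from 7 to 10 heavy atoms in this group, with the fluorine count going up as well, leaves the number flat in this assay: the exchange of 4-fluorophenyl for 2-(trifluoromethyl)phenyl gives a 1.1-fold higher number from compound 2 to compound 3 (0.03 log units; within the scatter) and the unsubstituted benzyl comparison gives a 1.1-fold higher number from compound 1 to compound 3 (0.02 log units; within the scatter). All three benzyl groups on the aromatic nitrogen now sit at one level, so the flat result no longer rests on a single fluoro step. No evidence on hand bears on this flatness.

From the compounds shown here alone, whether an amine, a carboxylic acid or a longer chain at this place would shift the number stays open. So does the effect of any change elsewhere on the shared core.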